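This account rests on a few compounds, and the source may have more. Where it says the series, first, only, none or still open, it means among the compounds named here.

Among the compounds with values here, compound 2 `COc1ccc(NC(=O)Nc2nc(Sc3c[nH]c4ccccc34)cc(N3CCN(c4ccccn4)CC3)n2)cc1` stands at the higher of the two numbers measured so far: in a functional assay on MDA-MB-231 cells (Homo sapiens) for inhibition, with a stated time of 72 h (on this read-out lower numbers stand for stronger inhibition and higher numbers for weaker inhibition), compound 2 gives 28400 nM, whereas compound 1 `COc1ccc(NC(=O)Nc2nc(Sc3c[nH]c4ccccc34)cc(N3CCCCC3)n2)cc1` gives 7260 nM. Compound 3 `COc1ccc(NC(=O)Nc2nc(Sc3c[nH]c4ccccc34)cc(N3CCN(Cc4ccccc4)CC3)n2)cc1` differs from compound 2 by benzyl in place of pyridin-2-yl on an amine nitrogen in a ring. Within the data shown here, the only measured step, a 3.9-fold higher number from compound 1 to compound 2 (0.59 log units; beyond the scatter), concerns a different change at a different place on the shared core, so no measured step bears directly on this swap. The step is therefore expected to be small, a 1.4-fold lower number from compound 2 to compound 3 (0.15 log units; within the scatter), with no clear direction. Compound 3 is estimated at 20000 nM, in a range from 6000 nM to 70000 nM.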

Compound 3, half-maximal inhibitory concentration: 8920 nM
Compound 3: middle estimate off by 2.2-fold (0.35 log units), on the high side, within the range that was stated.
By their numbers in this assay, from the lowest: compounds 1 and 3 (each within the scatter of the next); then compound 2.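

The group on this amine nitrogen clearly matters: in this assay, swapping pyridin-2-yl for benzyl gives a 3.2-fold lower number from compound 2 to compound 3 (0.50 log units; beyond the scatter). Compound 3 and compound 1 lie within the scatter of each other, so the piperazine ring does not always go with the higher number seen for compound 2. Nothing available explains the gap between these two groups. Still open, going by these compounds, is how a simple methyl on this nitrogen would compare, or a benzyl carrying a chlorine or a methoxy on its ring.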